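Dropping the fluoro from compound 2: a small change to test

This account rests on a few compounds, and the source may have more. Where it says the series, first, only, none or still open, it means among the compounds named here.

Two measured compounds frame this account. Compound 1, with the structure `CCOC(=O)c1nn(-c2ccc(Cl)cc2)c(-c2ccccc2)c1CNC(C)(C)C`, carries an ester and an unsubstituted phenyl group. In a functional assay on 786-0 cells (Homo sapiens) for inhibition, read by sulforhodamine B assay, with a stated time of 48 h (on this read-out higher numbers stand for weaker inhibition of growth and lower numbers for stronger inhibition of growth), compound 1 gives only limits of the assay, > 608000 nM; > 559000 nM (2 entries). Compound 2, with the structure `CC(C)(C)NCc1c(C(=O)O)nn(-c2ccc(Cl)cc2)c1-c1ccc(F)cc1`, carries a carboxylic acid and a 4-fluorophenyl group. In this assay compound 2 gives 204000 nM, the only number shown for it; a further entry for compound 2 carries no single number. Compound 1 and compound 2 differ in two places, so no single step can be read from their values; the limits of compound 1 are noted only as the several entries of compound 1 in this assay, > 608000 nM; > 559000 nM (2 entries).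

Compound 3, with the structure `CC(C)(C)NCc1c(C(=O)O)nn(-c2ccc(Cl)cc2)c1-c1ccccc1`, differs from compound 2 by hydrogen in place of fluoro on an aromatic carbon, which is hydrogen in place of fluoro on an aromatic carbon of a six-membered aromatic ring of carbon only.

From such a change no step beyond the scatter is expected in this assay, in either direction. The expected step of a 1.2-fold higher number from compound 2 to compound 3 (0.09 log units; within the scatter) is small. Compound 3 is estimated to give 250000 nM, within a range from 100000 nM to 600000 nM.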

Compound 3, concentration for 50% growth inhibition: > 652000 nM
Compound 3 was reported as a limit (the forecaster's own chance of this, stated with the estimate: 35%); at least 2.6-fold (0.41 log units) between middle value and limit.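

Compound 2 is the only compound shown with a single number in this assay, and the change from 4-fluorophenyl to phenyl gives an at least 3.1-fold higher number from compound 2 to compound 3 (0.50 log units; beyond the scatter) on this read-out. This shows that hydrogen in place of fluoro, on an aromatic carbon para to a large group, is not a silent change here: the compound that keeps the fluoro is the one that reads as a number, and the printed step gives only the least size the change can have, not its true size. Compound 3 stands as a limit, and the ester compound 1 with the same phenyl gives only limits too, so no step between those two can be read: the several entries of compound 1 in this assay, > 608000 nM; > 559000 nM (2 entries)

The compounds shown leave open whether this step belongs to fluoro itself or whether another group at the same place, such as chloro, methyl or methoxy, would also give a number rather than a limit. They also leave open how far compound 3 lies past its limit, and how an amide in place of the carboxylic acid would read on the 4-fluorophenyl compound.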